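Propoxy to 3-nitrophenoxy on the shared core

A few compounds are considered here, and "the series" means these few. Any claim that something is new, unique, unknown or untested is made for them only; others in the source may bear on it.

Going by the values given here, in a functional assay on HCT-116 cells (Homo sapiens) for inhibition, read by sulforhodamine B assay, with a stated time of 48 h, tested at 50 uM (a higher number here means more inhibition of growth at the concentration tested, a lower number less inhibition of growth), compound 1 (`CCCOc1ccc([C@@H]2CC(=O)c3cc(CC=C(C)C)c(OC)cc3O2)cc1`) gives 63% and compound 2 (`COc1ccc([C@@H]2C/C(=N/OCc3cn(-c4ccc(O)cc4)nn3)c3cc(CC=C(C)C)c(OC)cc3O2)cc1`) gives 65% with the two values inside the scatter of each other, so compound 1 stands level with the only other number available. Going to compound 3 (`COc1cc2c(cc1CC=C(C)C)C(=O)C[C@@H](c1ccc(Oc3cccc([N+](=O)[O-])c3)cc1)O2`) puts 3-nitrophenyl in place of propyl on an oxygen on an aromatic ring. Among the compounds with values here, no measured step covers this change, so no shift beyond the scatter is expected in this assay in either direction. The estimated step is a number 3 percentage points lower from compound 1 to compound 3 (within the scatter) and remains a judgement. For compound 3 the expected value is 60% with an estimated range from 38% to 80% as a wide margin.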

Compound 3, percent growth inhibition at one concentration: 46%
Estimate against measurement, compound 3: 14 percentage points above, and the stated range covers the measured number.
By their numbers in this assay, from the lowest: compound 3; then compounds 1 and 2 (each within the scatter of the next).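

Going by these compounds alone, on an oxygen on an aromatic ring, replacing propyl with 3-nitrophenyl gives the only readable step: in this assay there is a number 17 percentage points lower from compound 1 to compound 3 (beyond the scatter), a loss of growth inhibition beyond the scatter. For this pair, the position is therefore not indifferent to the group on that oxygen. No available evidence accounts for the step.

As far as these compounds go, whether the added ring or the nitro group carries the step remains open. Plain phenyl or butyl on the same oxygen would test this further.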